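From compound 3 to compound 4: one added methoxy

A few compounds are considered here, and "the series" means these few. Any claim that something is new, unique, unknown or untested is made for them only; others in the source may bear on it.

Measured in an ADME assay on BJ cells (Homo sapiens) for cytotoxicity, read by luminescence, with a stated time of 72 h (a lower number here means that less compound is needed, a higher number that more compound is needed for the effect), where each value is a limit of the assay:
compound 1 `CCOC(=O)c1c(-c2cc(F)cc(OC)c2)[nH]c2cc(OC)ccc2c1=O`: > 21500 nM
compound 2 `CCOC(=O)c1c(-c2cc(F)cc(OC)c2)[nH]c2cc(OC)c(Cl)cc2c1=O`: > 21500 nM
compound 3 `CCOC(=O)c1c(-c2cccc(F)c2)[nH]c2cc(OC)c(F)cc2c1=O`: > 21500 nM

Compound 3 gives no number to start from, only the limit > 21500 nM. Going by the values given here, the series so far shows (the limit of > 21500 nM in this assay, at which 3 of the 3 values shown sit). Compound 4 `CCOC(=O)c1c(-c2cc(F)cc(OC)c2)[nH]c2cc(OC)c(F)cc2c1=O` differs from compound 3 at one place: methoxy in place of hydrogen on an aromatic carbon. The change turns 3-fluorophenyl into 3-fluoro-5-methoxyphenyl.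

Among the compounds with values here, the one measured step, a step that the two limits leave unreadable from compound 1 to compound 2, concerns chloro in place of hydrogen, a different change, and it offers no size to carry over. The better guide is the 3-fluoro-5-methoxyphenyl group itself. Compound 1 carries this group and gives only the limit > 21500 nM. Compound 2 carries it too and gives only the limit > 21500 nM. No step beyond the scatter is therefore expected in this assay, in either direction, and compound 4 will most likely also report only a limit. Should a number appear, the estimate for compound 4 is 25000 nM, within an expected range from 14000 nM to 45000 nM. The expected step is a step that the limit leaves unreadable from compound 3 to compound 4.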

Compound 4, half-maximal effective concentration: > 21500 nM
Compound 4 ended at the assay's limit; the forecaster's own chance of this, stated with the estimate: 85%; the middle value is on the limit's open side.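

In this assay compound 4 gives > 21500 nM, which is a limit of the assay. No step from compound 1, compound 2 or compound 3 to compound 4 can be read, and the series rests on one limit: the limit of > 21500 nM in this assay, at which 4 of the 4 values shown sit.

The compounds shown leave open how far any of the four lies past that limit, and whether the methoxy, fluoro or chloro changes alter the read-out at all.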